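Changing One Aryl Ring on the Amide Carbonyl

The source may hold more compounds than are shown below. What is called first, only, known or untested is meant among the compounds shown, and "the series" means these compounds.

Compound 1, `Cc1ccc(S(=O)(=O)NCc2ccc(CNC(=O)c3ccc(F)cc3)cc2)cc1`, gives 1 nM in an assay on MDA-MB-231 cells for binding affinity to C-X-C chemokine receptor type 4 (Homo sapiens), read by immunofluorescence and microscopy, with stated times of 10 min and 30 min; on this read-out lower numbers stand for an effect already at smaller amounts and higher numbers for an effect only at larger amounts of compound.
Compound 2, `COc1ccccc1C(=O)NCc1ccc(CNS(=O)(=O)c2ccccc2)cc1`, gives 1 nM in this assay.
Compound 3, `COc1ccccc1C(=O)NCc1ccc(CNS(=O)(=O)c2ccc(C)cc2)cc1`, gives 100 nM in this assay.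

Compound 2 stands level with compound 1 at the lowest number of the three, and far from compound 3: the step of a 100-fold higher number from compound 2 to compound 3 (2.00 log units; beyond the scatter) is large. Compound 4, `Cc1cccc(C(=O)NCc2ccc(CNS(=O)(=O)c3ccccc3)cc2)c1`, is not yet measured; it differs from compound 2 by 3-methylphenyl in place of 2-methoxyphenyl on a carbonyl carbon. The step at this same carbonyl position, a 100-fold higher number from compound 1 to compound 3 (2.00 log units; beyond the scatter), was also large, but there compound 3 carries the extra methyl that compound 2 lacks, so it is uncertain how much of it transfers. The data give no direct case of the change at hand, so a small step, if any, beyond the scatter is expected, a 2.0-fold higher number from compound 2 to compound 4 (0.30 log units; within the scatter). Compound 4 is therefore estimated at 2 nM, between 0.5 nM and 15 nM.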

Compound 4, effective concentration (reported as EC, without a stated level of effect): 1000 nM
Estimate against measurement, compound 4: 500-fold (2.70 log units) below; measured number outside the range, above it.
By their numbers in this assay, from the lowest: compounds 1 and 2 (each within the scatter of the next); then compound 3; then compound 4.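

With the rest of compound 2 unchanged, 3-methylphenyl in place of 2-methoxyphenyl on the carbonyl carbon gives a 1000-fold higher number from compound 2 to compound 4 (3.00 log units; beyond the scatter) in this assay, so this ring can shift the number strongly even when the other end of the molecule carries no methyl. The swap changes both the group and where it sits on the ring, and it drops the hydrogen-bond acceptor counted in the leaving group, and these compounds cannot separate those differences. No measured evidence accounts for the jump.

Going by these compounds, it remains open how this ring would read with an amine or a carboxylic acid on it, and whether a longer chain in place of the methyl would bring the number back down.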